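Swapping Acetyl for Methylsulfanyl on the Oxime Carbon

The source may hold more compounds than are shown below. What is called first, only, known or untested is meant among the compounds shown, and "the series" means these compounds.

Within the data shown here, compound 1 `CC(=O)/C(=N\O)c1ccc(Sc2cc(F)cc(C3CCOCC3)c2)cc1` has the higher of the two numbers measured so far in a functional assay (blood) for inhibition, with Homo sapiens as the target (a lower number here means a stronger inhibitor, a higher number a weaker inhibitor), giving 850 nM. Compound 2 `CO[C@]1(c2cc(F)cc(Sc3ccc(/C(C)=N/O)cc3)c2)CCO[C@@H](C)C1` gives 40 nM in this assay, a gap well beyond the usual scatter. Compound 3 `CS/C(=N\O)c1ccc(Sc2cc(F)cc(C3CCOCC3)c2)cc1` has not yet been measured; it differs from compound 1 in a single place: methylsulfanyl in place of acetyl on a carbon with a double bond to nitrogen. Among the measured compounds shown here, no measured pair shows the effect of this change, so the step is expected to be small, a 1.4-fold lower number from compound 1 to compound 3 (0.15 log units; within the scatter), with no clear direction. Compound 3 is therefore estimated at 600 nM in this assay, within a range from 150 nM to 2500 nM.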

Compound 3, half-maximal inhibitory concentration: 190 nM
Compound 3: middle estimate off by 3.2-fold (0.50 log units), on the high side; measured number inside the range.
By their numbers in this assay, from the lowest: compound 2; then compound 3; then compound 1.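

On a carbon with a double bond to nitrogen, the choice of group clearly matters in this assay: methylsulfanyl in place of acetyl gives a 4.5-fold lower number from compound 1 to compound 3 (0.65 log units; beyond the scatter), beyond the usual scatter. Among these compounds, this is the first comparison here that isolates a single change, since compound 1 and compound 2 differ in more than one place. Nothing shown here explains the step.

From the compounds shown here alone, whether methoxy, ethylsulfanyl or an amine on this carbon would give a lower number remains open. So does whether methylsulfanyl would have a similar effect on the core of compound 2.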